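Removing the central methoxy from the trimethoxy dienamide

The source may hold more compounds than are shown below. What is called first, only, known or untested is meant among the compounds shown, and "the series" means these compounds.

Compound 1 `COc1cc(/C=C/C=C/C(=O)N2CCCCC2)cc(OC)c1OC` carries three methoxy groups on its aromatic ring and is the highest of the three measured compounds in an assay for inhibition of Polyunsaturated fatty acid 5-lipoxygenase (Homo sapiens), read by spectrophotometry, tested at 20 uM (on this read-out lower numbers stand for less inhibition and higher numbers for more inhibition at the one concentration tested (going by the name of the read-out)), where compound 1 gives 66.7%. Compound 3 `COc1ccc(/C=C/C=C/C(=O)N2CCCCC2)cc1OC` keeps two methoxy groups and in this assay compound 3 gives 51.9%; the change amounts to a number 14.8 percentage points lower from compound 1 to compound 3 (beyond the scatter). Compound 2 `O=C(/C=C/C=C/c1ccc(F)cc1)N1CCCCC1` carries a single fluorine on the ring instead, and in this assay compound 2 gives 48.7%, the lowest of the three.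

Compound 4 `COc1cc(/C=C/C=C/C(=O)N2CCCCC2)cc(OC)c1` differs from compound 1 by hydrogen in place of methoxy on an aromatic carbon. For the measured compounds named here, the only measured step of the same kind, hydrogen in place of methoxy on an aromatic carbon, is the one from compound 1 to compound 3, which lowered the read-out beyond the scatter. Although the methoxy removed here sits at a different place, ortho to two methoxy groups and para to a large group, a loss of similar size is expected, so the estimated step is a number 13.7 percentage points lower from compound 1 to compound 4 (beyond the scatter). For compound 4 the estimate in this assay is 53%, expected between 40% and 66%.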

Compound 4, a percentage reported as inhibition, at one concentration (the size of the read-out at that concentration, not a potency): 64.9%
Estimate against measurement, compound 4: 11.9 percentage points below; low and high end bracket the measured number.
By their numbers in this assay, from the lowest: compounds 2 and 3 (each within the scatter of the next); then compounds 4 and 1 (each within the scatter of the next).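

In this assay, the methoxy that is ortho to two methoxy groups and para to a large group can give way to hydrogen with a step of a number 1.8 percentage points lower from compound 1 to compound 4 (within the scatter), so the read-out of compound 1 does not depend measurably on this group. The same change elsewhere on the ring gave a number 14.8 percentage points lower from compound 1 to compound 3 (beyond the scatter), so the loss seen there does not carry over to this position, and the outcome of removing a methoxy from compound 1 depends on which one leaves. Nothing available accounts for this difference between the two positions.

Still open, going by these compounds, is whether a hydroxyl or an amine at this position would stay level with hydrogen or move the read-out. Also open, on these data alone, is what removing a further methoxy from compound 4 would do.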